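Carboxy to 1,2-dihydroxyethyl on a coumarin-type amide side chain

The source may report more compounds than this note shows. Statements on the series, on what has been measured and on what is new or still open speak of the compounds shown alone.

Measured compounds:
compound 1 `COc1cccc2cc(C(=O)NCC(=O)O)c(=O)oc12` with 27%
compound 2 `N=c1oc2ccc(Br)cc2cc1C(=O)NCCO` with 26%

In an assay on CHO cells for displacement of a labelled ligand from adenosine receptor A1 (Homo sapiens), read by scintillation counting, with a stated time of 60 min, tested at 10 uM (on this read-out lower numbers stand for less inhibition and higher numbers for more inhibition at the one concentration tested (going by the name of the read-out)), compound 1 gives 27%, and compound 2 gives 26%; the two numbers lie within the usual scatter of each other, so neither stands apart. Compound 3 `COc1cccc2cc(C(=O)NCC(O)CO)c(=O)oc12` has not been measured. It differs from compound 1 by 1,2-dihydroxyethyl in place of carboxy on a saturated chain carbon bound to an amide-type nitrogen. For the measured compounds named here, no step between measured compounds shows how such a change plays out here. Compound 3 is expected to stay near compound 1, with a step of a number 2 percentage points lower from compound 1 to compound 3 (within the scatter) that is not beyond the scatter. Compound 3 is estimated at 25%, in the range 5% to 45%.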

Compound 3, a percentage reported as inhibition, at one concentration (the size of the read-out at that concentration, not a potency): 14%
Beside the measured number, compound 3's estimate is 11 percentage points above it, within the range that was stated.
By their numbers in this assay, from the lowest: compound 3; then compounds 2 and 1 (each within the scatter of the next).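

In this assay the group on a saturated chain carbon bound to an amide-type nitrogen does matter: 1,2-dihydroxyethyl in place of carboxy gives a number 13 percentage points lower from compound 1 to compound 3 (beyond the scatter) with the rest of the structure unchanged. For the compounds shown here, this is the first step to show that this place responds at all, and its size is modest. No measurement at hand accounts for the step. Going by these compounds, whether the drop comes with losing carboxy or with gaining 1,2-dihydroxyethyl stays open. So does whether an amine or a longer chain at this place would hold the level of compound 1.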